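Methyl branching on the ester and amide side chains

The compounds below may be only part of what the source reports. "The series", "measured", "known", "first", "only" and "open" are said of these compounds alone.

Measured in an assay on membranes from HEK293 cells for displacement of a labelled ligand from adenosine receptor A2b (Homo sapiens), read by scintillation counting, with a stated time of 30 min, tested at 1 uM; on this read-out lower numbers stand for less inhibition and higher numbers for more inhibition at the one concentration tested (going by the name of the read-out):
compound 1 `CCCOC(=O)C1=C(C)N(C)C(=O)NC1c1ccsc1` gives 1%
compound 2 `CC1=C(C(=O)OCC(C)C)C(c2ccsc2)NC(=O)N1C` gives 1%
compound 3 `CCNC(=O)C1=C(C)NC(=O)NC1c1ccsc1` gives 1%

All three measured compounds sit at the bottom of the read-out in this assay. Compound 1 and compound 2 differ by methyl in place of hydrogen on a saturated chain carbon bound to two saturated chain carbons, and the change gives no change at the digits printed from compound 1 to compound 2 (within the scatter). Compound 3 carries a different core; the difference between the core of compound 3 and the core of compound 1 is not broken down here. In this assay compound 3 is level with compound 1 and compound 2 at the digits given, within the scatter of both.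

Compound 4 `CC1=C(C(=O)NC(C)C)C(c2ccsc2)NC(=O)N1` has not yet been measured. It differs from compound 3 by methyl in place of hydrogen on a saturated chain carbon bound to an amide-type nitrogen and a saturated chain carbon. Among the compounds with values here, this is the same kind of change as the one from compound 1 to compound 2, but not the same: there the place was a saturated chain carbon bound to two saturated chain carbons, here it is a saturated chain carbon bound to an amide-type nitrogen and a saturated chain carbon.

For compound 4 the step in this assay is expected to be no change at the digits printed from compound 3 to compound 4 (within the scatter), because no change at the digits printed from compound 1 to compound 2 (within the scatter) shows the like change leaving the read-out flat and because compound 3 already gives 1%. No compound shown goes against this. Compound 4 is therefore estimated at 1%, within -8% to 12%.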

Compound 4, a percentage reported as inhibition, at one concentration (the size of the read-out at that concentration, not a potency): 3%
Estimate against measurement, compound 4: 2 percentage points below; low and high end bracket the measured number.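

In this assay, the change from ethylcarbamoyl to isopropylcarbamoyl gives a number 2 percentage points higher from compound 3 to compound 4 (within the scatter). Set beside the earlier step, the added methyl reads alike on the two cores: the same change on two cores in this assay, no change at the digits printed (within the scatter) from compound 1 to compound 2 and a number 2 percentage points higher (within the scatter) from compound 3 to compound 4, 2 percentage points apart, within the scatter of two such steps

This shows only that, at the one concentration tested, the added methyl does not lift either pair off the bottom of the read-out, whether it sits on a saturated chain carbon bound to two saturated chain carbons or on one bound to an amide-type nitrogen and a saturated chain carbon; with all four compounds at that level, the agreement does not show that a measurable effect of this change carries from one core to the other, and one pair per core with the change at a different place on each cannot settle that.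

The compounds shown leave open whether a longer chain, or an amine or a carboxylic acid at the end of the side chain, would move the read-out at all, and whether the added methyl would still read alike on the two cores from such a higher level. From the compounds shown here alone, the separate contributions of the ester and amide side chains and the other differences between the core of compound 1 and the core of compound 3 also stay open, since those two compounds differ in more than one place.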